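This account rests on a few compounds, and the source may have more. Where it says the series, first, only, none or still open, it means among the compounds named here.

Working notes on the series. Compound 1 `Cc1nc(S(C)(=O)=O)ccc1Oc1ncnc(OC2CCN(C(=O)OC(C)C)CC2)c1F` gives 77% in a functional assay on isolated protein for inhibition of Glucose-dependent insulinotropic receptor (Rattus norvegicus), read by HTRF and cAMP accumulation; on this read-out higher numbers stand for larger maximal responses and lower numbers for smaller maximal responses. Compound 2 `Cc1nc(S(C)(=O)=O)ccc1Oc1ncnc(OC2CCN(C(=O)O[C@H](C)C(F)(F)F)CC2)c1F` gives 85% in this assay, and compound 3 `Cc1nc(S(C)(=O)=O)ccc1Oc1ncnc(OC2CCN(C(=O)SC3CCC3)CC2)c1F` gives 81%. On these three numbers compound 3 stands second highest, with compound 1 nearest and compound 2 furthest; both gaps lie within the scatter, so the three compounds cannot be separated on this read-out.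

Compound 4 `Cc1nc(S(C)(=O)=O)ccc1Oc1ncnc(OC2CCN(C(=O)C(C)(C)F)CC2)c1F` differs from compound 3 in one place: 1-fluoro-1-methylethyl in place of cyclobutylsulfanyl on a carbonyl carbon. The measured steps that bear on this position are the exchanges on the same carbonyl carbon: a number 4 percentage points higher from compound 1 to compound 3 (within the scatter) and a number 4 percentage points lower from compound 2 to compound 3 (within the scatter). Among the compounds with values here, both lie within the scatter, and so does a number 8 percentage points higher from compound 1 to compound 2 (within the scatter), the only other step. Within the data shown here, every change tried so far at this end of the molecule has left the maximal response where it was, and the entering 1-fluoro-1-methylethyl group is simply a further variation at the same carbonyl carbon with no measured precedent of its own.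

No step beyond the scatter is therefore expected, and the estimated change is a number 1 percentage points lower from compound 3 to compound 4 (within the scatter). For compound 4 the expected value in this assay is 80%, with a range from 68% to 92%.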

Compound 4, largest response reached (reported as efficacy), in percent of the reference or control that the assay uses: 74%
The estimate for compound 4 lay 6 percentage points above the measured number, and the stated range covers the measured number.
By their numbers in this assay, from the lowest: compounds 4, 1, 3 and 2 (each within the scatter of the next, the first and the last beyond it).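

In this assay, within the data shown here, this carbonyl carbon now gives its first step beyond the scatter, a number 11 percentage points lower from compound 2 to compound 4 (beyond the scatter), so 1-fluoro-1-methylethyl and 1-(trifluoromethyl)ethoxy can be told apart at this position, although the step is modest and no earlier pair could be separated. The other two exchanges give a number 7 percentage points lower from compound 3 to compound 4 (within the scatter) and a number 3 percentage points lower from compound 1 to compound 4 (within the scatter), so compound 4 cannot be separated from compound 3 or compound 1, and the one separation in the series rests on a single pair of compounds rather than on a general effect of the entering group. Nothing available bears on why this one pair separates while the other exchanges at the position do not.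

Going by these compounds, it remains open whether a dimethylamino group or a longer alkyl chain on the same carbonyl carbon would stay level with compound 4 or with compound 2. On these data alone, it is equally open whether the separation between compound 2 and compound 4 would carry over to any read-out other than maximal response.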